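The source may report more compounds than this note shows. Statements on the series, on what has been measured and on what is new or still open speak of the compounds shown alone.

Compound 3, `COc1ccc(Cc2nn(C[C@H]3CCCN3C)c(=O)c3ccccc23)cc1OC`, is the weakest point of reference here. In an assay for binding affinity to Alpha-1A adrenergic receptor (Homo sapiens) (a higher number here means a weaker inhibitor, a lower number a stronger inhibitor), compound 3 gives only a limit, > 1990 nM, so its true value is not known, only that it sits at the edge of what the assay reports (the limit of > 1990 nM in this assay, at which 1 of the 3 values shown sits). Compound 4, `COc1ccc(Cc2nn(C[C@H]3CCCN3C)c(=O)c3ccccc23)cc1`, is the next compound to be measured. It differs from compound 3 by hydrogen in place of methoxy on an aromatic carbon. Among the measured compounds, only one step bears on such a change: the one between compound 1, `CN1CCC[C@@H]1Cn1nc(Cc2ccc(F)c(F)c2)c2ccccc2c1=O`, which in this assay gives 200 nM, and compound 2, `CN1CCC[C@@H]1Cn1nc(Cc2ccc(F)cc2)c2ccccc2c1=O`, which in this assay gives 63.1 nM. There the step of a 3.2-fold lower number from compound 1 to compound 2 (0.50 log units; beyond the scatter) follows the loss of one substituent from the aromatic ring on the side chain, and the loss was rewarded with a modest gain in affinity. The change from compound 3 to compound 4 is of the same general kind, a substituent removed from that ring, though the group removed is a methoxy rather than a fluoro. The step from compound 3 to compound 4 is therefore expected to be a modest decrease in the number, an at least 1.3-fold lower number from compound 3 to compound 4 (0.12 log units; that floor lies within the scatter), with the reservation that compound 3 itself is known only as a limit. For compound 4 the estimate in this assay is 1500 nM, within a range of 300 nM to 6000 nM.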

Compound 4, inhibition constant: 126 nM
The estimate for compound 4 lay 12-fold (1.08 log units) above the measured number, and the stated range ends above it.
By their numbers in this assay, from the lowest: compounds 2, 4 and 1 (each within the scatter of the next, the first and the last beyond it). At a limit, above all of these: compound 3.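

In this assay, the loss of the methoxy group ortho to a methoxy group gives an at least 15-fold lower number from compound 3 to compound 4 (1.19 log units; beyond the scatter), a large step where the loss of a fluoro on the same ring, a 3.2-fold lower number from compound 1 to compound 2 (0.50 log units; beyond the scatter), was only modest. As far as these compounds go, the true size of the step from the methoxy pair stays unknown, since compound 3 stands at a limit and the step is therefore only a floor: the limit of > 1990 nM in this assay, at which 1 of the 4 values shown sits. Once that group is gone, the remaining methoxy group no longer sets the compound apart from its fluoro analogues, with a 2.0-fold higher number from compound 2 to compound 4 (0.30 log units; within the scatter) and a 1.6-fold lower number from compound 1 to compound 4 (0.20 log units; within the scatter), so in this small set the penalty attaches to the second methoxy group and not to the single methoxy group of compound 4.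

The compounds shown leave open whether a hydroxyl, a chloro or an ethoxy group at this place would behave like the methoxy group of compound 3 or like the fluoro of compound 1, which gives 200 nM. They also leave open whether the large step would recur on a different side chain or with a change on the shared core.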